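The source may report more compounds than this note shows. Statements on the series, on what has been measured and on what is new or still open speak of the compounds shown alone.

Measured in an ADME assay on S9 fraction from liver (Homo sapiens) for metabolic stability, with a stated time of 1 h; on this read-out higher numbers stand for a more stable compound and lower numbers for a less stable compound:
- Compound 1 `CO[C@H]1CC[C@@H](Nc2cc(NCc3cnccc3C(F)(F)F)ncc2C#N)CC1`: 19%
- Compound 2 `CNC(=O)[C@H]1CC[C@@H](Nc2cc(NCc3cnccc3C(F)(F)F)ncc2C#N)CC1`: 71%

Compound 2 holds the higher of the two numbers, at 71%. Compound 3 `CN(C)C(=O)[C@H]1CC[C@@H](Nc2cc(NCc3cnccc3C(F)(F)F)ncc2C#N)CC1` has methyl in place of hydrogen on an amide-type nitrogen. Going by the values given here, one measured step bears on this, and only indirectly: a number 52 percentage points higher from compound 1 to compound 2 (beyond the scatter), a large step beyond the scatter that replaced the whole group rather than altering this nitrogen. Among the compounds with values here, no measured step shows the change itself, so a moderate fall in this assay is expected, though no change remains possible. The expected step is a number 11 percentage points lower from compound 2 to compound 3 (beyond the scatter). Compound 3 is estimated at 60%, with an expected range of 38% to 80%.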

Compound 3, percent of the compound remaining: 48%
The estimate for compound 3 lay 12 percentage points above the measured number; the range from low to high includes it.
By their numbers in this assay, from the lowest: compound 1; then compound 3; then compound 2.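

In this assay, the nitrogen of the methylcarbamoyl group is itself sensitive to change: methyl in place of the amide hydrogen gives a number 23 percentage points lower from compound 2 to compound 3 (beyond the scatter). Dimethylcarbamoyl on the saturated ring carbon still keeps a gain over methoxy, with a number 29 percentage points higher from compound 1 to compound 3 (beyond the scatter), so the gain does not rest entirely on the amide hydrogen. Nothing measured here explains either step. As far as these compounds go, it remains open how a longer chain such as ethyl on this nitrogen would read in this assay, or how a carboxylic acid or an amine would read in place of the whole amide.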